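Two substituent changes traced across four related compounds

The compounds below may be only part of what the source reports. "The series", "measured", "known", "first", "only" and "open" are said of these compounds alone.

Compound 1 `CCOc1ccc(NC(=O)c2ccc(C(CC)(CC)c3ccc(OCC(=O)C(C)(C)C)c(C)c3)n2CC)cc1` was tested in an assay on HL-60 cells for agonist activity at vitamin D3 receptor (Homo sapiens), read by microscopy, with a stated time of 96 h; on this read-out lower numbers stand for an effect already at smaller amounts and higher numbers for an effect only at larger amounts of compound. In this assay compound 1 gives only a limit, > 50000 nM, and not a number; this is the limit of > 50000 nM in this assay, at which 1 of the 3 values shown sits. Compound 2 `CCOC(=O)c1ccc(OC(=O)c2ccc(C(CC)(CC)c3ccc(OCC(=O)C(C)(C)C)c(C)c3)n2CC)cc1` differs from compound 1 by 4-(ethoxycarbonyl)phenoxy in place of (4-ethoxyphenyl)amino on a carbonyl carbon. In this assay compound 2 gives 45600 nM, so the step is an at least 1.0-fold lower number from compound 1 to compound 2 (0.04 log units; that floor lies within the scatter). Compound 3 `CCOc1ccc(NC(=O)c2ccc(C(CC)(CC)c3ccc(OCC(O)C(C)(C)C)c(C)c3)n2CC)cc1` carries a change on the other side of the shared core, and in this assay compound 3 gives 630 nM, a step of an at least 79-fold lower number from compound 1 to compound 3 (1.89 log units; beyond the scatter).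

Compound 4 `CCOC(=O)c1ccc(OC(=O)c2ccc(C(CC)(CC)c3ccc(OCC(O)C(C)(C)C)c(C)c3)n2CC)cc1` has not yet been measured. It differs from compound 3 by 4-(ethoxycarbonyl)phenoxy in place of (4-ethoxyphenyl)amino on a carbonyl carbon, the same change already made from compound 1 to compound 2, on the same kind of carbonyl carbon bound to an aromatic carbon. The cores of compound 3 and compound 1 differ by 1-hydroxy-2,2-dimethylpropyl in place of (tert-butyl)carbonyl on a saturated chain carbon bound to an oxygen on an aromatic ring.

For compound 4 a step of about a 1.1-fold lower number from compound 3 to compound 4 (0.02 log units; within the scatter) is expected in this assay, since the earlier step in compound 2 was an at least 1.0-fold lower number from compound 1 to compound 2 (0.04 log units; that floor lies within the scatter), within the scatter, although it started from a limit. Compound 4 is therefore estimated at 600 nM, within roughly 150 nM to 2500 nM.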

Compound 4, half-maximal effective concentration: > 50000 nM
Compound 4: no number, only a limit (the forecaster's own chance of this, stated with the estimate: 5%); middle value at least 83-fold (1.92 log units) away from the limit.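

Carried onto the core of compound 3, the change to 4-(ethoxycarbonyl)phenoxy gives an at least 79-fold higher number from compound 3 to compound 4 (1.89 log units; beyond the scatter) in this assay, a step that rests on a limit at its upper end, so its effect does not transfer from one core to the other: the same change on two cores in this assay, an at least 1.0-fold lower number (0.04 log units; that floor lies within the scatter) from compound 1 to compound 2 and an at least 79-fold higher number (1.89 log units; beyond the scatter) from compound 3 to compound 4, at least 87-fold (1.93 log units) apart, beyond the scatter of two such steps

Read the other way, the change to 1-hydroxy-2,2-dimethylpropyl gives only an at least 1.0-fold higher number from compound 2 to compound 4 (0.04 log units; that floor lies within the scatter), again against a limit, so it does not transfer either: the same change on two cores in this assay, an at least 79-fold lower number (1.89 log units; beyond the scatter) from compound 1 to compound 3 and an at least 1.0-fold higher number (0.04 log units; that floor lies within the scatter) from compound 2 to compound 4, at least 87-fold (1.93 log units) apart, beyond the scatter of two such steps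

These steps are floors and do not show how far either compound at the limit lies from the others, nor why only compound 3 gives a measured number near the lower end of the series: the limit of > 50000 nM in this assay, at which 2 of the 4 values shown sit.

The compounds shown leave open which part of the entering group matters, the ethyl ester or the oxygen on the carbonyl carbon. A carboxylic acid in place of the ethyl ester, or an amine on the aromatic ring, might separate the two.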